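The source may report more compounds than this note shows. Statements on the series, on what has been measured and on what is new or still open speak of the compounds shown alone.

Measured compounds:
compound 1, `CC(c1ccc(-c2ccccc2)c(F)c1)c1nnc2n1N=C(c1ccc(Cl)cc1Cl)CS2`, gives 6900 nM in a functional assay on HCT-116 cells (Homo sapiens) for inhibition, read by sulforhodamine B assay, with a stated time of 72 h; on this read-out higher numbers stand for weaker inhibition and lower numbers for stronger inhibition;
compound 2, `CC(c1ccc(-c2ccccc2)c(F)c1)c1nnc2n1N=C(c1ccc(C(F)(F)F)cc1)CS2`, gives 6100 nM in this assay.

On the numbers shown, compound 2 sits together with compound 1: the step of a 1.1-fold lower number from compound 1 to compound 2 (0.05 log units; within the scatter) is within the scatter, and no other compound has been measured in this assay. Compound 3, `COc1ccc(C2=Nn3c(nnc3C(C)c3ccc(-c4ccccc4)c(F)c3)SC2)cc1`, has not yet been measured. It differs from compound 2 by methoxy in place of trifluoromethyl on an aromatic carbon. For the measured compounds named here, the one measured step that bears on this change is a 1.1-fold lower number from compound 1 to compound 2 (0.05 log units; within the scatter), in which the whole aryl group on the carbon with a double bond to nitrogen was exchanged without moving the number beyond the scatter. A smaller exchange at that same place is expected to behave alike, with no step beyond the scatter in this assay. Compound 3 is therefore estimated to give 6000 nM in this assay, within a range from 2500 nM to 15000 nM. The expected step is a 1.0-fold lower number from compound 2 to compound 3 (0.01 log units; within the scatter).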

Compound 3, half-maximal inhibitory concentration: 4400 nM
Compound 3: middle estimate off by 1.4-fold (0.13 log units), on the high side; the measured number falls inside the stated range.
By their numbers in this assay, from the lowest: compounds 3, 2 and 1 (each within the scatter of the next).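

Putting methoxy in place of trifluoromethyl on the aromatic carbon para to a large group gives a 1.4-fold lower number from compound 2 to compound 3 (0.14 log units; within the scatter) in this assay. The group entering holds one hydrogen-bond acceptor and the group leaving holds none, yet the number stays within the scatter. The exchange of 2,4-dichlorophenyl for 4-methoxyphenyl gives a 1.6-fold lower number from compound 1 to compound 3 (0.20 log units; within the scatter), so all three aryl groups shown sit together at this place in this assay. No measurement is at hand that would account for this.

As far as these compounds go, whether an amine or a carboxylic acid on that same aromatic carbon would also stay within the scatter remains open. The rest of the structure is the same in all three compounds, so the effect of a change anywhere else cannot be told from them.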